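Toward Compound 4: Changing the Amide Substituent

A few compounds are considered here, and "the series" means these few. Any claim that something is new, unique, unknown or untested is made for them only; others in the source may bear on it.

Compound 1 `CC(C)c1c(C(=O)N(C)Cc2ccccc2)nn(-c2ccc(F)cc2)c1CC[C@@H](O)C[C@@H](O)CC(=O)O` and compound 2 `CC(C)c1c(C(=O)N2CCC[C@H](N3CCC4C=CC=CC4C3)C2)nn(-c2ccc(F)cc2)c1CC[C@@H](O)C[C@@H](O)CC(=O)O` set the frame for this series. In a functional assay on L6 cells (Rattus norvegicus) for inhibition (a higher number here means a weaker inhibitor, a lower number a stronger inhibitor), compound 1 gives 2870 nM, and compound 2 gives 1720 nM; the gap between these two values is no larger than the usual scatter of such measurements, so neither can be called the stronger inhibitor. Compound 3 `COc1ccc(CNC(=O)c2nn(-c3ccc(F)cc3)c(OC[C@@H](O)C[C@@H](O)CC(=O)O)c2C(C)C)cc1` belongs to a variant of the shared core, and in this assay compound 3 gives "not determined" (no result reported), so no single number was reported for it. Compound 4 `COc1cccc(CN(C)C(=O)c2nn(-c3ccc(F)cc3)c(OC[C@@H](O)C[C@@H](O)CC(=O)O)c2C(C)C)c1` differs from compound 3 at one place only: (3-methoxybenzyl)(methyl)amino in place of (4-methoxybenzyl)amino on a carbonyl carbon. No step between measured compounds bears on this change, so its direction in this assay cannot be taken from the shown values; a shift within the scatter, or a small one in either direction, is all that can be expected. Compound 4 resembles compound 1 in its methylated amide, and compound 1 gives 2870 nM, which serves as the nearest anchor. On that basis compound 4 is expected to give about 2500 nM in this assay, with a range from 600 nM to 10000 nM to reflect the lack of a measured step.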

Compound 4, half-maximal inhibitory concentration: 9460 nM
The estimate for compound 4 lay 3.8-fold (0.58 log units) below the measured number; low and high end bracket the measured number.
By their numbers in this assay, from the lowest: compounds 2 and 1 (each within the scatter of the next); then compound 4.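

Within the data shown here, compound 3 has no single number in this assay, so no step to compound 4 can be read, even though compound 4 gives 9460 nM there. The compounds shown leave open how the (3-methoxybenzyl)(methyl)amino group compares with the (4-methoxybenzyl)amino group on this core. No available evidence bears on this result.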